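This account rests on a few compounds, and the source may have more. Where it says the series, first, only, none or still open, it means among the compounds named here.

Compound 3 `Cc1ccc(-[n+]2noc([O-])c2CN2CCN(c3cccc(Cl)c3Cl)CC2)cc1` gives 31.7 ug/mL in an ADME assay on MT4 cells (Homo sapiens) for cytotoxicity, read by MTT assay; on this read-out lower numbers stand for higher toxicity in this test and higher numbers for lower toxicity in this test. Among the three compounds measured it stands second highest: compound 1 `Cc1ccc(-[n+]2noc([O-])c2CN2CCNCC2)cc1` gives 32.6 ug/mL, a number within the scatter of that of compound 3, while compound 2 `[O-]c1on[n+](-c2ccc(Cc3ccc(-[n+]4noc([O-])c4CN4CCCCC4)cc3)cc2)c1CN1CCCCC1` gives 12.1 ug/mL, a number beyond the scatter below it. Compound 4 `CC(=O)N1CCN(Cc2c([O-])on[n+]2-c2ccc(C)cc2)CC1` differs from compound 3 by acetyl in place of 2,3-dichlorophenyl on an amine nitrogen in a ring. Among the measured compounds shown here, one measured step bears on this position, a 1.0-fold lower number from compound 1 to compound 3 (0.01 log units; within the scatter), where a new group on the amine nitrogen in the ring left the number within the scatter. On that basis the expected step in this assay is a 1.0-fold higher number from compound 3 to compound 4 (0.00 log units; within the scatter), none beyond the scatter. Compound 4 is therefore estimated at 32 ug/mL, with a range from 16 ug/mL to 64 ug/mL.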

Compound 4, half-maximal cytotoxic concentration: 17.3 ug/mL
Beside the measured number, compound 4's estimate is 1.8-fold (0.27 log units) above it, and the stated range covers the measured number.
By their numbers in this assay, from the lowest: compounds 2, 4, 3 and 1 (each within the scatter of the next, the first and the last beyond it).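

In this assay both new steps of a 1.8-fold lower number from compound 3 to compound 4 (0.26 log units; within the scatter) and a 1.9-fold lower number from compound 1 to compound 4 (0.28 log units; within the scatter) stay within the scatter. Acetyl, with no ring and with its hydrogen-bond acceptor, thus joins hydrogen and 2,3-dichlorophenyl on this amine nitrogen in a ring without a step beyond the scatter among the three. Nothing at hand accounts for these numbers. The compounds shown leave open whether any group on this nitrogen moves the number beyond the scatter in this assay. A carboxylic acid or an aminoethyl chain there remains untested in what is shown.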